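Amide nitrogen substituent and thermodynamic solubility

The source may hold more compounds than are shown below. What is called first, only, known or untested is meant among the compounds shown, and "the series" means these compounds.

Compound 2 `COCCNC(=O)c1cc2c(C)cc(C)cc2[nH]1` carries a 2-methoxyethyl group on the amide nitrogen. For the measured compounds named here, in a physicochemical assay for solubility, measured as thermodynamic solubility, with a stated time of 24 h, at pH 6.8 (a higher number here means a more soluble compound, a lower number a less soluble compound), compound 2 gives 620000 nM, the only proper number obtained so far. Compound 1 `Cc1cc(C)c2cc(C(=O)N[C@@H]3CCCC[C@@H]3C)[nH]c2c1` carries a 2-methylcyclohexyl group on the same nitrogen, and in this assay compound 1 gives < 4000 nM, which is a limit of the assay and not a number. Going by the values given here, the single measured step, an at least 150-fold higher number from compound 1 to compound 2 (2.19 log units; beyond the scatter), is therefore bounded on one side by the limit of < 4000 nM in this assay, at which 1 of the 2 values shown sits, so its true size is open upward. Compound 3 `Cc1cc(C)c2cc(C(=O)NC3CCOCC3)[nH]c2c1` is the next member: oxan-4-yl in place of 2-methoxyethyl on an amide-type nitrogen. This change runs partly against the measured step, since a six-membered ring again replaces the open chain on the amide nitrogen, while the one oxygen acceptor is kept. A drop in this assay beyond the scatter is expected, though the measured step gives no footing for one as large as that seen with compound 1. The expected step is a 6.2-fold lower number from compound 2 to compound 3 (0.79 log units; beyond the scatter). For compound 3 the estimate in this assay is 100000 nM, with a range from 20000 nM to 400000 nM.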

Compound 3, solubility: 17000 nM
Estimate against measurement, compound 3: 5.9-fold (0.77 log units) above; measured number outside the range, below it.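

Replacing 2-methoxyethyl with oxan-4-yl, two groups that match in hydrogen-bond donors, hydrogen-bond acceptors and net charge, gives a 36-fold lower number from compound 2 to compound 3 (1.56 log units; beyond the scatter) in this assay, so matching those counts does not keep the number high. The second step, an at least 4.2-fold higher number from compound 1 to compound 3 (0.62 log units; beyond the scatter), places oxan-4-yl between the other two groups on the amide nitrogen, so a six-membered ring there does not by itself bring the number down to the level of the 2-methylcyclohexyl compound. That second step stays open upward, and the value of compound 1, < 4000 nM, is a limit of the assay and not a number: the limit of < 4000 nM in this assay, at which 1 of the 3 values shown sits.

The compounds shown leave open whether the large drop belongs to the ring itself or to the larger group, which a longer open chain such as 3-methoxypropyl, with the ring absent, would help to separate. They also leave open how much of the remaining gap belongs to the ring oxygen and how much to the methyl of 2-methylcyclohexyl, a question that a plain cyclohexyl group on the same nitrogen would address.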